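The compounds below may be only part of what the source reports. "The series", "measured", "known", "first", "only" and "open" are said of these compounds alone.

Of the compounds shown here, two built on one shared core have been measured in a functional assay on L1210 cells (Mus musculus) for cytotoxicity, read by cell counting, with a stated time of 2 days; a higher number here means a weaker inhibitor, a lower number a stronger inhibitor. Compound 1 `C=C(Br)C(=O)Nc1ccc(/C=C2\SC(=O)N(Cc3ccccc3)C2=O)cc1` gives 1100 nM in this assay. Compound 2 `C=C(Br)C(=O)Nc1ccc(/C=C2\SC(=O)N(Cc3ccc(F)cc3)C2=O)cc1` gives 2200 nM in this assay. On these two numbers compound 2 stands beside compound 1, separated only by a 2.0-fold higher number from compound 1 to compound 2 (0.30 log units; within the scatter), a step that a repeat measurement could easily undo.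

Compound 3 `C=C(Br)C(=O)Nc1ccc(/C=C2\SC(=O)N(Cc3cccc(F)c3)C2=O)cc1` differs from compound 2 in one change: 3-fluorophenyl in place of 4-fluorophenyl on a saturated chain carbon bound to an amide-type nitrogen in a ring. Going by the values given here, the single measured step, in which a fluorine arrived on the same ring, stayed within the scatter; no measured pair shows what moving that fluorine does. The expected outcome for compound 3 in this assay is therefore no step beyond the scatter, a 1.1-fold lower number from compound 2 to compound 3 (0.04 log units; within the scatter). Compound 3 is estimated at 2000 nM in this assay, with a range from 900 nM to 4500 nM.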

Compound 3, half-maximal inhibitory concentration: 1200 nM
Beside the measured number, compound 3's estimate is 1.7-fold (0.22 log units) above it; low and high end bracket the measured number.
By their numbers in this assay, from the lowest: compounds 1, 3 and 2 (each within the scatter of the next).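

In this assay, going by these compounds alone, the swap of 4-fluorophenyl for 3-fluorophenyl gives a 1.8-fold lower number from compound 2 to compound 3 (0.26 log units; within the scatter) and is the first measured test of where the fluorine sits on this ring; the two placements cannot be told apart here. Compared with the ring without fluorine, the new placement gives a 1.1-fold higher number from compound 1 to compound 3 (0.04 log units; within the scatter) and so also stays within the scatter, as the 4-fluorophenyl step did. No supporting measurement is available to explain these numbers.

Both fluorine placements leave the number close to that of the unsubstituted ring, so this position has not yet shown any real sensitivity. Going by these compounds, whether a larger or different group, such as a methoxy group, an amine or a carboxylic acid on this ring, or a longer chain in place of the benzyl, would produce a step beyond the scatter remains open.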